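Changing the End Group on a Growth Inhibitor

The compounds below may be only part of what the source reports. "The series", "measured", "known", "first", "only" and "open" are said of these compounds alone.

- Compound 1 `Cc1ccc2[nH]c(-c3ccc(-c4ccc(-c5ccc(N(C)C)cc5)cc4)cc3)nc2c1`: 3510 nM
- Compound 2 `FC(F)(F)c1ccc(-c2ccc(-c3ccc(-c4nc5ccccc5[nH]4)cc3)cc2)cc1`: 36600 nM
- Compound 3 `FC(F)(F)Oc1ccc(-c2ccc(-c3ccc(-c4nc5ccccc5[nH]4)cc3)cc2)cc1`: 38000 nM

In a functional assay on A549 cells (Homo sapiens) for inhibition, read by sulforhodamine B assay (a lower number here means a stronger inhibitor of growth, a higher number a weaker inhibitor of growth), compound 2 gives 36600 nM, which lies within the scatter of compound 3, while compound 1 shows a lower number. Compound 4 `COc1ccc(-c2ccc(-c3ccc(-c4nc5ccccc5[nH]4)cc3)cc2)cc1OC` is still unmeasured and differs from compound 2 at one end, on an aromatic carbon: 3,4-dimethoxyphenyl in place of 4-(trifluoromethyl)phenyl on an aromatic carbon. One measured step changes that same end: a 1.0-fold higher number from compound 2 to compound 3 (0.02 log units; within the scatter). It stays within the scatter, but it brings in a different group. Compound 1 has another end group and also differs elsewhere, so it offers only a loose hint toward lower numbers. A modest change toward a lower number is expected: a 2.4-fold lower number from compound 2 to compound 4 (0.39 log units; beyond the scatter). For compound 4 the estimated value is 15000 nM, with an expected range from 4000 nM to 50000 nM.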

Compound 4, concentration for 50% growth inhibition: 7600 nM
Compound 4: middle estimate off by 2.0-fold (0.30 log units), on the high side; the range from low to high includes it.
By their numbers in this assay, from the lowest: compound 1; then compound 4; then compounds 2 and 3 (each within the scatter of the next).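

In this assay, the end group at this position can shift the number beyond the scatter: a 4.8-fold lower number from compound 2 to compound 4 (0.68 log units; beyond the scatter), whereas a 1.0-fold higher number from compound 2 to compound 3 (0.02 log units; within the scatter) stayed within it. The 3,4-dimethoxyphenyl group brings hydrogen-bond acceptors that 4-(trifluoromethyl)phenyl lacks, but this difference alone does not show what drives the step. No available evidence explains the change in growth inhibition. Going by these compounds, it remains open whether a single methoxy group at this end would give a similar number. On these data alone, how a carboxylic acid or a nitrile would behave there also remains open.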